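3-Hydroxyphenyl versus 4-hydroxyphenyl in two related series

The source may report more compounds than this note shows. Statements on the series, on what has been measured and on what is new or still open speak of the compounds shown alone.

Compound 1 `Oc1ccc(-c2cc(-c3ccccc3C(F)(F)F)cc(-c3cccc(O)c3)n2)cc1` carries two hydroxyphenyl groups on the shared core and, in a functional assay on T47D cells (Homo sapiens) for inhibition (a lower number here means a stronger inhibitor, a higher number a weaker inhibitor), compound 1 gives 3210 nM. Compound 2 `Oc1ccc(-c2cc(-c3ccccc3C(F)(F)F)cc(-c3ccc(O)cc3)n2)cc1` differs from it by 4-hydroxyphenyl in place of 3-hydroxyphenyl on an aromatic carbon. In this assay compound 2 reaches only the assay limit, > 50000 nM. The resulting step is an at least 15-fold higher number from compound 1 to compound 2 (1.19 log units; beyond the scatter); its true size cannot be fixed because the pair rests on (the limit of > 50000 nM in this assay, at which 1 of the 3 values shown sits).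

Compound 3 `Oc1cccc(-c2cc(-c3ccccc3OC(F)(F)F)cc(-c3cccc(O)c3)n2)c1` belongs to a second core; the difference between the two cores is not broken down here. In this assay compound 3 gives 7950 nM, the higher of the two numbers measured, with compound 1 as its nearest neighbour.

Compound 4 `Oc1ccc(-c2cc(-c3ccccc3OC(F)(F)F)cc(-c3cccc(O)c3)n2)cc1` is not yet measured. It differs from compound 3 by 4-hydroxyphenyl in place of 3-hydroxyphenyl on an aromatic carbon. The surroundings are not identical to those in the first pair: in compound 3 the changed carbon is meta to a 3-hydroxyphenyl group and meta to a large group, whereas in compound 1 it is meta to a 2-(trifluoromethyl)phenyl group and meta to a 4-hydroxyphenyl group, so the change is of the same kind, not the same.

For the measured compounds named here, the step from compound 3 to compound 4 is expected to be a 13-fold higher number from compound 3 to compound 4 (1.10 log units; beyond the scatter), of a size like the one seen from compound 1 to compound 2. That expectation rests on compound 1 moving to a limit by an at least 15-fold higher number from compound 1 to compound 2 (1.19 log units; beyond the scatter) after this same kind of change. Compound 4 is therefore estimated at 100000 nM, between 30000 nM and 400000 nM, and most likely reported only as a limit.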

Compound 4, half-maximal inhibitory concentration: 7300 nM
Compound 4: the middle estimate sits 14-fold (1.14 log units) above what was measured; the whole stated range lies above it.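

In this assay, the exchange of 3-hydroxyphenyl for 4-hydroxyphenyl does not carry from the core of compound 1 to the core of compound 3, and the two steps differ: the same change on two cores in this assay, an at least 15-fold higher number (1.19 log units; beyond the scatter) from compound 1 to compound 2 and a 1.1-fold lower number (0.04 log units; within the scatter) from compound 3 to compound 4, at least 16-fold (1.22 log units) apart, beyond the scatter of two such steps. On the core of compound 3 the change gives a 1.1-fold lower number from compound 3 to compound 4 (0.04 log units; within the scatter), so the large step seen on the core of compound 1 cannot be taken as a rule for this exchange, while trifluoromethoxy in place of trifluoromethyl, with both hydroxyphenyl groups kept, gives a 2.3-fold higher number from compound 1 to compound 4 (0.36 log units; beyond the scatter). For the compounds shown here, this does not show why the outcome depends on the core, and with only two pairs it sets no rule for the series; the gap also has no upper bound, as compound 2 is reported only as a limit: the limit of > 50000 nM in this assay, at which 1 of the 4 values shown sits.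

As far as these compounds go, the two steps also differ in the hydroxyphenyl group that stays in place, so it remains open whether that group or the trifluoromethoxy group separates them, and a compound carrying two 4-hydroxyphenyl groups together with the 2-(trifluoromethoxy)phenyl group would separate the two. Also open, from the compounds shown here alone, is whether the hydroxyl itself is needed in either position, a question that an amine or a methoxy group in its place would address.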